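A chloro to fluoro swap on the sulfur-bound benzyl group

The source may report more compounds than this note shows. Statements on the series, on what has been measured and on what is new or still open speak of the compounds shown alone.

compound 1 `COc1ccc(C2N=C(SCc3ccccc3Cl)NC(C)=C2C(=O)Nc2ccc(Br)cc2)cc1`: 13.3%
compound 2 `COc1ccc(C2N=C(SCc3ccc(Cl)cc3)NC(C)=C2C(=O)Nc2ccc(Br)cc2)cc1`: 30.3%

In a functional assay on the whole organism (artery, strain albino) with Rattus norvegicus as the target, with a stated time of 600 min, at a dose of 10 mg/kg by the oral route (on this read-out lower numbers stand for less inhibition and higher numbers for more inhibition at the one dose given (going by the name of the read-out)), compound 2 gives 30.3%, the higher of the two numbers shown. Compound 1 gives 13.3%. Within the data shown here, the only measured step, a number 17 percentage points higher from compound 1 to compound 2 (beyond the scatter), exchanges 2-chlorophenyl for 4-chlorophenyl and keeps the chlorine, so it bears only loosely on the move to compound 3 `COc1ccc(C2N=C(SCc3ccc(F)cc3)NC(C)=C2C(=O)Nc2ccc(Br)cc2)cc1`, which is fluoro in place of chloro on an aromatic carbon. Among the measured compounds shown here, no measured pair here replaces one halogen by another, so the expected step is a number 4.3 percentage points lower from compound 2 to compound 3 (within the scatter), within the usual scatter. For compound 3 the estimate is 26%, with a range from 10% to 42%.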

Compound 3, a percentage reported as inhibition, in the whole organism at one dose (the size of the read-out at that dose, not a potency): 24.1%
For compound 3 the middle estimate is 1.9 percentage points above the measured one; low and high end bracket the measured number.
By their numbers in this assay, from the lowest: compound 1; then compounds 3 and 2 (each within the scatter of the next).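

At this aromatic carbon, fluoro in place of chloro gives a number 6.2 percentage points lower from compound 2 to compound 3 (within the scatter) in this assay, so this read-out does not separate the two halogens here. The 4-fluorophenyl group also stays clear of the 2-chlorophenyl group, with a number 10.8 percentage points higher from compound 1 to compound 3 (beyond the scatter), so among these three compounds the 2-chlorophenyl compound alone stands apart. Nothing measured on these compounds offers an explanation for either step. The compounds shown leave open whether an amine or a carboxylic acid on this same carbon would hold the number seen with chloro and fluoro.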